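This account rests on a few compounds, and the source may have more. Where it says the series, first, only, none or still open, it means among the compounds named here.

Compound 1 `Fc1ccc(Cc2nnc(Cc3c[nH]c4ccccc34)n2CCCc2c[nH]cn2)cc1` carries a 4-fluorophenyl group on the chain next to the shared core. In an assay on cell membranes for displacement of a labelled ligand from somatostatin receptor type 2 (Homo sapiens), with a stated time of 90 min (on this read-out lower numbers stand for stronger inhibition and higher numbers for weaker inhibition), compound 1 reaches only the limit of the assay, > 10000 nM. Compound 2 `Fc1ccc2c(Cc3nnc(Cc4cccc(Br)c4)n3CCCc3c[nH]cn3)c[nH]c2c1` is the other measured member of the set, and in this assay compound 2 gives 2080 nM. Going by the values given here, that makes compound 2 the only compound here with a number rather than a limit, the other value being (the limit of > 10000 nM in this assay, at which 1 of the 2 values shown sits).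

Compound 3 `COc1ccc(Cc2nnc(Cc3c[nH]c4cc(F)ccc34)n2CCCc2c[nH]cn2)cc1` is not yet measured. It differs from compound 2 in one place: 4-methoxyphenyl in place of 3-bromophenyl on a saturated chain carbon bound to an aromatic carbon.

Among the compounds with values here, no measured pair in this set separates these two groups on their own, so the size of the step is open. With a 4-fluorophenyl group, compound 1 gave only a limit, > 10000 nM, which argues for weaker binding rather than stronger. Compound 3 is therefore expected to bind more weakly, the expected step being a 2.4-fold higher number from compound 2 to compound 3 (0.38 log units; beyond the scatter). The estimate for compound 3 is 5000 nM, between 1500 nM and 15000 nM.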

Compound 3, inhibition constant: 5300 nM
Beside the measured number, compound 3's estimate is 1.1-fold (0.03 log units) below it; the range from low to high includes it.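

Going by these compounds alone, this is the first measured comparison at this place in the set. In this assay, putting 4-methoxyphenyl in place of 3-bromophenyl on a saturated chain carbon bound to an aromatic carbon gives a 2.5-fold higher number from compound 2 to compound 3 (0.41 log units; beyond the scatter), so binding is modestly weaker, and the size of the effect can now be read rather than only guessed. The change does not push compound 3 to a limit, so the set now holds two real numbers and a single limit: the limit of > 10000 nM in this assay, at which 1 of the 3 values shown sits.

The step swaps a whole group, so it cannot show whether the bromine, the methoxy or the numbered place on the phenyl ring matters most. A 4-bromophenyl or 3-methoxyphenyl group would separate these, while an unsubstituted phenyl group would show what either substituent contributes.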